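The source may hold more compounds than are shown below. What is called first, only, known or untested is meant among the compounds shown, and "the series" means these compounds.

Measured compounds:
compound 1 `Nc1cc(N)c2nc(-c3ccccc3)c(Oc3ccc(Cl)c(Cl)c3)nc2c1`, 24500 nM
compound 2 `COc1cc(CNc2nc3cc(N)cc(N)c3nc2-c2ccccc2)cc(OC)c1OC`, 6310 nM

In a functional assay on TK-10 cells (Homo sapiens) for inhibition, read by sulforhodamine B assay, with a stated time of 48 h (on this read-out lower numbers stand for stronger inhibition of growth and higher numbers for weaker inhibition of growth), compound 1 gives 24500 nM, the higher of the two numbers, while compound 2 gives 6310 nM, a gap beyond the scatter. Within the data shown here, no pair of measured compounds differs in only one place, so no single step can be read off. Compound 3 `Nc1cc(N)c2nc(-c3ccccc3)c(Sc3ccc(Cl)c(Cl)c3)nc2c1` differs from compound 1 by (3,4-dichlorophenyl)sulfanyl in place of 3,4-dichlorophenoxy on an aromatic carbon, next to the ring nitrogen and ortho to a phenyl group. With no comparable swap measured, the change from compound 1 to compound 3 is expected to be small, a 1.2-fold lower number from compound 1 to compound 3 (0.09 log units; within the scatter), with no clear direction. Compound 3 is estimated at 20000 nM, within a range from 7000 nM to 60000 nM.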

Compound 3, concentration for 50% growth inhibition: 5890 nM
The estimate for compound 3 lay 3.4-fold (0.53 log units) above the measured number; the measured number lies below the stated range.
By their numbers in this assay, from the lowest: compounds 3 and 2 (each within the scatter of the next); then compound 1.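

In this assay, among these compounds, putting (3,4-dichlorophenyl)sulfanyl in place of 3,4-dichlorophenoxy gives a 4.2-fold lower number from compound 1 to compound 3 (0.62 log units; beyond the scatter), the only single-place comparison in this set. The atom joining the dichlorophenyl ring to the shared core therefore matters at this position, next to the ring nitrogen and ortho to a phenyl group, even though the two groups have the same number of heavy atoms. Nothing here explains why the sulfur-linked compound gives the lower number. Going by these compounds, it remains open whether a (3,4-dichlorophenyl)amino or a (3,4-dichlorophenyl)sulfonyl group at this position would lower the number further. On these data alone, whether the same swap has a similar effect on other cores also remains open.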